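The source may hold more compounds than are shown below. What is called first, only, known or untested is meant among the compounds shown, and "the series" means these compounds.

Measured so far, in an assay on isolated protein for inhibition of Ephrin type-A receptor 2 (Homo sapiens), read by thermal shift assay, tested at 10 uM; a lower number here means that the compound stabilises the target less, a higher number that the compound stabilises the target more against heat:

compound 1, `CCOc1ccc(NC(=O)Nc2cc(C(C)(C)C)nn2-c2ccccc2)cc1`: 1 degrees C
compound 2, `Cc1cc(C)cc(NC(=O)Nc2cc(C(C)(C)C)nn2-c2ccccc2)c1`: 0.7 degrees C

Both compounds share the core with a tert-butyl group and a phenyl on the pyrazole-type ring; they differ only in the aryl group on the urea nitrogen. The step of a number 0.30 degrees C lower from compound 1 to compound 2 (within the scatter) is the only one recorded, and it lies within the scatter, so the two values cannot be placed in order. Compound 2 sits at the lower of the two numbers, with compound 1 the nearest, but the gap says nothing beyond noise.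

The next compound, compound 3, `Cc1ccc(F)cc1NC(=O)Nc1cc(C(C)(C)C)nn1-c1ccccc1`, keeps the same core and changes the aryl group once more: 5-fluoro-2-methylphenyl in place of 3,5-dimethylphenyl on an amide-type nitrogen.

Among the compounds with values here, only the step from compound 1 to compound 2 bears on this change, and it was within the scatter. Moving from one substitution pattern on the aryl ring to another has so far produced no step beyond the scatter, and nothing recorded points to a direction for compound 3. The expectation is therefore a step of a number 0.10 degrees C higher from compound 2 to compound 3 (within the scatter), that is, none beyond the scatter. For compound 3 the estimated shift in this assay is 0.8 degrees C, in the range 0 degrees C to 1.8 degrees C.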

Compound 3, shift of the target's melting temperature: 1.6 degrees C
Estimate against measurement, compound 3: 0.80 degrees C below; measured number inside the range.
By their numbers in this assay, from the lowest: compounds 2, 1 and 3 (each within the scatter of the next).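

In this assay, 5-fluoro-2-methylphenyl on the amide-type nitrogen gives a number 0.90 degrees C higher from compound 2 to compound 3 (within the scatter), and against the 4-ethoxyphenyl group the same substituent gives a number 0.60 degrees C higher from compound 1 to compound 3 (within the scatter). The fluorine-bearing aryl group therefore adds a third substitution pattern at this position, and all three aryl groups remain within the scatter of one another, so the series still has no order at this nitrogen and no single substituent stands out. No supporting data bear on this result.

The compounds shown leave open whether any group on this nitrogen can produce a step beyond the scatter, as every group here is a substituted phenyl ring carrying only methyl, ethoxy or fluorine, so a phenyl ring bearing a carboxylic acid or an amine, or a saturated cyclohexyl group, would test a wider range. On these data alone, the tert-butyl and phenyl groups of the shared core also stay the same throughout, so the response of this assay to a change at either of those places remains unknown.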